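Notes on the substituent at the aromatic nitrogen

The source may hold more compounds than are shown below. What is called first, only, known or untested is meant among the compounds shown, and "the series" means these compounds.

Of the compounds shown here, two have numbers so far. Compound 1 `CCOCCn1c(N2CCCN(Cc3ccccc3)CC2)nc2ccccc21` gives 15 nM in a functional assay on ileum for inhibition of histamine H1 receptor (Cavia porcellus); a lower number here means a stronger inhibitor, a higher number a weaker inhibitor. Compound 2 `CN1CCN(c2nc3ccccc3n2-c2ccccc2)CC1` gives 760 nM in this assay and stands highest of the two, a gap from compound 1 that is well beyond the scatter. Compound 3 `CCCC(C)n1c(N2CCN(C)CC2)nc2ccccc21` has not been measured; it differs from compound 2 by 1-methylbutyl in place of phenyl on an aromatic nitrogen. Among the compounds with values here, no single-change step between measured compounds exists, so this change is untested; compound 1 carries a chain rather than a ring at that nitrogen but also a different amine. A moderate fall in the number is expected, a 3.8-fold lower number from compound 2 to compound 3 (0.58 log units; beyond the scatter). Compound 3 is estimated at 200 nM, within 40 nM to 1000 nM.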

Compound 3, half-maximal inhibitory concentration: 1400 nM
Beside the measured number, compound 3's estimate is 7.0-fold (0.85 log units) below it; the measured number lies above the stated range.
By their numbers in this assay, from the lowest: compound 1; then compounds 2 and 3 (each within the scatter of the next).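

In this assay, 1-methylbutyl in place of phenyl on the aromatic nitrogen gives a 1.8-fold higher number from compound 2 to compound 3 (0.27 log units; within the scatter), so compound 2 and compound 3 cannot be told apart. With the 4-methylpiperazin-1-yl group in place, this position therefore tolerates a group with no ring as well as the six-membered aromatic ring, and the exchange does not shift the number beyond the scatter. Nothing at hand offers an explanation for this result. Still open, from the compounds shown here alone, is whether a longer chain, or a chain ending in an amine or a carboxylic acid, would move the number at this nitrogen. Also open, going by these compounds, is whether the exchange would read the same with another amine in place of the 4-methylpiperazin-1-yl group.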